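The compounds below may be only part of what the source reports. "The series", "measured", "known", "first", "only" and "open" are said of these compounds alone.

Values so far in a functional assay (Nicotiana tabacum) (on this read-out higher numbers stand for weaker inhibition and lower numbers for stronger inhibition), and the open case:
- compound 1 `CCCCCNc1nc(SC)nc2ncccc12` at 650 nM
- compound 2 `CSc1nc(NC2CCCC2)c2cccnc2n1` at 490 nM
- compound 3 `CCC(CC)Nc1nc(SC)nc2ncccc12` not yet measured

Compound 2 at 490 nM lies within the scatter of compound 1 at 650 nM and the two cannot be ranked. The next change is pentan-3-yl in place of cyclopentyl on a nitrogen on an aromatic ring with pentan-3-yl in place of cyclopentyl on a nitrogen on an aromatic ring. Within the data shown here, one measured step bears on it: a 1.3-fold lower number from compound 1 to compound 2 (0.12 log units; within the scatter) where cyclopentyl replaced pentyl. Nothing beyond the scatter is therefore expected in this assay and the expected move is a 1.2-fold higher number from compound 2 to compound 3 (0.09 log units; within the scatter) at most a small one. Compound 3 is estimated at 600 nM with an expected range of 250 nM to 1400 nM for now.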

Compound 3, half-maximal inhibitory concentration: 2720 nM
Compound 3: the middle estimate sits 4.5-fold (0.66 log units) below what was measured; measured number above the stated range.
By their numbers in this assay, from the lowest: compounds 2 and 1 (each within the scatter of the next); then compound 3.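

In this assay the carbon count of the group on this nitrogen does not settle the read-out: cyclopentyl and pentan-3-yl both hold 5 carbons, yet opening the ring gives a 5.6-fold higher number from compound 2 to compound 3 (0.74 log units; beyond the scatter) here. The branched chain also parts from the straight one, with a 4.2-fold higher number from compound 1 to compound 3 (0.62 log units; beyond the scatter), although pentyl and cyclopentyl could not be ranked. No measurement at hand explains this difference.

Still open, on these data alone, is whether cyclohexyl, a shorter chain such as propyl, or a hydroxyl on the pentyl chain would hold the lower numbers.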